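A few compounds are considered here, and "the series" means these few. Any claim that something is new, unique, unknown or untested is made for them only; others in the source may bear on it.

Compound 1 `COc1ccc(S(=O)(=O)Nc2ccc(Cl)c3cc[nH]c23)cc1`: 1.1 ug/mL
Compound 2 `O=S(=O)(Nc1ccc(Cl)c2cc[nH]c12)c1ccc(Cl)cc1`: 4.6 ug/mL
Compound 3 `O=[N+]([O-])c1ccc(S(=O)(=O)Nc2ccc(Cl)c3cc[nH]c23)cc1`: 3.3 ug/mL

These values all come from a functional assay on P388 cells (Mus musculus) for antiproliferative activity, read by colorimetric assay and MTT assay; on this read-out lower numbers stand for stronger inhibition and higher numbers for weaker inhibition. Compound 3 lies within the scatter of compound 2, and both give higher numbers than compound 1. The next compound is compound 4 `N#Cc1ccc(S(=O)(=O)Nc2ccc(Cl)c3cc[nH]c23)cc1`, with cyano in place of nitro on an aromatic carbon. Three measured steps changed the same place. Leaving methoxy gave modest rises, a 4.2-fold higher number from compound 1 to compound 2 (0.62 log units; beyond the scatter) and a 3.0-fold higher number from compound 1 to compound 3 (0.48 log units; beyond the scatter). Swapping chloro for nitro gave only a 1.4-fold lower number from compound 2 to compound 3 (0.14 log units; within the scatter), which is within the scatter. Neither cyano nor nitro is methoxy, so the smaller step is the closer guide, and no step beyond the scatter is expected. The expected change is a 1.1-fold lower number from compound 3 to compound 4 (0.04 log units; within the scatter). For compound 4 the estimated value is 3 ug/mL, with an expected range of 1.3 ug/mL to 7 ug/mL.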

Compound 4, half-maximal inhibitory concentration: 1.8 ug/mL
The estimate for compound 4 lay 1.7-fold (0.22 log units) above the measured number; low and high end bracket the measured number.
By their numbers in this assay, from the lowest: compounds 1, 4, 3 and 2 (each within the scatter of the next, the first and the last beyond it).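

In this assay, cyano is the only replacement for methoxy at this place that stays within the scatter (a 1.6-fold higher number from compound 1 to compound 4 (0.21 log units; within the scatter)), and it is also the only one of the two newer groups to separate from chloro (a 2.6-fold lower number from compound 2 to compound 4 (0.41 log units; beyond the scatter)). Cyano and nitro still cannot be told apart (a 1.8-fold lower number from compound 3 to compound 4 (0.26 log units; within the scatter)), so this swap adds no clear difference of its own. Nothing available here explains these results.
From the compounds shown here alone, whether an amine, a carboxylic acid or a longer chain at this place would stay within this narrow span of values remains open. So does whether plain hydrogen there would give a higher or lower number than methoxy.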